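Removing one chloro group from a dichloro compound

The compounds below may be only part of what the source reports. "The series", "measured", "known", "first", "only" and "open" are said of these compounds alone.

In a functional assay on HeLa cells (Homo sapiens) for cytotoxicity, read by sulforhodamine B assay, with a stated time of 48 h (on this read-out higher numbers stand for weaker inhibition and lower numbers for stronger inhibition), the measured compounds stand as follows.

Compound 1 `O=C(c1cccnc1)c1cc(F)ccc1O` gives 27000 nM

Compound 2 `O=C(c1cccnc1)c1ccccc1O` gives 33000 nM

Compound 3 `O=C(c1cccnc1)c1cc(Cl)cc(Cl)c1O` gives > 100000 nM

Compound 3 reaches no number in this assay and stands only at a limit, > 100000 nM, which is the limit of > 100000 nM in this assay, at which 1 of the 3 values shown sits. Compound 4 `O=C(c1cccnc1)c1cc(Cl)ccc1O` has not yet been measured. It differs from compound 3 by one change, (hydrogen in place of chloro on an aromatic carbon), so hydrogen takes the place of chloro on an aromatic carbon, ortho to a hydroxy group, while the other chloro group stays.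

For the measured compounds named here, only one measured step bears on this change. It is a 1.2-fold higher number from compound 1 to compound 2 (0.09 log units; within the scatter), where hydrogen replaces fluoro on an aromatic carbon. Going by the values given here, that step removes a different halogen, so no measured step shows directly what losing a chloro group does. Among the compounds with values here, compound 1 at 27000 nM and compound 2 at 33000 nM are the only compounds with numbers, and they suggest where a compound of this series may land. A move towards a lower number, meaning stronger inhibition, is therefore expected, and the expected size is an at least 3.3-fold lower number from compound 3 to compound 4 (0.52 log units; beyond the scatter). For compound 4 the estimated value is 30000 nM, with an expected range from 12000 nM to 75000 nM.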

Compound 4, half-maximal inhibitory concentration: 24000 nM
Estimate against measurement, compound 4: 1.3-fold (0.10 log units) above; measured number inside the range.
By their numbers in this assay, from the lowest: compounds 4, 1 and 2 (each within the scatter of the next). At a limit, above all of these: compound 3.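

In this assay, for the compounds shown here, hydrogen in place of chloro on the aromatic carbon ortho to a hydroxy group gives an at least 4.1-fold lower number from compound 3 to compound 4 (0.61 log units; beyond the scatter), the first step that lies beyond the scatter, and it shows that this position can matter where the earlier halogen step could not show it. Compound 3 stands only at a limit, not at a number: the limit of > 100000 nM in this assay, at which 1 of the 4 values shown sits. At the place of the remaining chloro group, the picture differs, since a 1.4-fold lower number from compound 2 to compound 4 (0.14 log units; within the scatter) and a 1.1-fold lower number from compound 1 to compound 4 (0.05 log units; within the scatter) both lie within the scatter, so chloro, fluoro and hydrogen at that place are not told apart in this assay.

From the compounds shown here alone, what an amine, a methoxy group or a carboxylic acid would give on the carbon ortho to a hydroxy group stays open, as does whether any group other than chloro at that place would move the number in the same way. Also open, going by these compounds, is how far compound 3 lies beyond its limit, so the full size of its step to compound 4 remains unknown.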